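The compounds below may be only part of what the source reports. "The series", "measured", "known", "first", "only" and "open" are said of these compounds alone.

Measured in a toxicity assay on MCF-10A cells (Homo sapiens) for cytotoxicity, read by MTT assay, with a stated time of 48 h; on this read-out lower numbers stand for stronger inhibition and higher numbers for weaker inhibition:
compound 1 `O=C(/C=C/c1ccc2c(c1)B(O)OC2)c1ccccc1` gives 15900 nM
compound 2 `Cn1cccc1C(=O)/C=C/c1ccc2c(c1)B(O)OC2` gives > 100000 nM
compound 3 `O=C(/C=C/c1ccc2c(c1)B(O)OC2)c1ccc(F)cc1` gives 11800 nM

The value for compound 2 is a limit of the assay (the limit of > 100000 nM in this assay, at which 1 of the 3 values shown sits). Among the two numbers, compound 1 holds the higher one, with compound 3 nearest: a 1.3-fold lower number from compound 1 to compound 3 (0.13 log units; within the scatter). The exchange of the ring on the carbonyl carbon gives an at least 6.2-fold higher number from compound 1 to compound 2 (0.79 log units; beyond the scatter).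

Compound 4 `Cc1cccc(C(=O)/C=C/c2ccc3c(c2)B(O)OC3)c1` differs from compound 1 by methyl in place of hydrogen on an aromatic carbon. The step that bears on this is the fluoro for hydrogen exchange on an aromatic carbon, a 1.3-fold lower number from compound 1 to compound 3 (0.13 log units; within the scatter), which stayed within the scatter. For compound 4 a step of similar size is expected, a 1.1-fold lower number from compound 1 to compound 4 (0.06 log units; within the scatter), none beyond the scatter. Compound 4 is therefore estimated at 14000 nM, with a range from 6000 nM to 35000 nM.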

Compound 4, half-maximal inhibitory concentration: 15900 nM
For compound 4 the middle estimate is 1.1-fold (0.06 log units) below the measured one; the measured number falls inside the stated range.
By their numbers in this assay, from the lowest: compounds 3, 1 and 4 (each within the scatter of the next). At a limit, above all of these: compound 2.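

In this assay, methyl in place of hydrogen on an aromatic carbon, meta to a large group, gives no change at the digits printed from compound 1 to compound 4 (within the scatter), so this position carries a methyl without a readable shift. Against the fluorinated ring, 3-methylphenyl in place of 4-fluorophenyl gives a 1.3-fold higher number from compound 3 to compound 4 (0.13 log units; within the scatter). The exchange of 1-methyl-1H-pyrrol-2-yl for 3-methylphenyl gives an at least 6.2-fold lower number from compound 2 to compound 4 (0.79 log units; beyond the scatter), a step that starts from a limit of the assay: the limit of > 100000 nM in this assay, at which 1 of the 4 values shown sits.

Going by these compounds, whether an amine, a carboxylic acid or a longer chain on this same carbon would move the number beyond the scatter stays open.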